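The source may hold more compounds than are shown below. What is called first, only, known or untested is meant among the compounds shown, and "the series" means these compounds.

Compound 1 `CCCCNc1nc(N)nc2c1CN(C)CC2` is the reference point in an assay on HEK293 cells for agonist activity at Toll-like receptor 8 (Homo sapiens), read by a luciferase reporter, with a stated time of 6 h (on this read-out higher numbers stand for an effect only at larger amounts of compound and lower numbers for an effect already at smaller amounts), where compound 1 gives 0.03 uM. Among the three compounds measured so far it holds the lowest number: compound 2 `CCCCNc1nc(N)nc2c1CN(Cc1c(Cl)cccc1Cl)CC2` gives 0.14 uM and compound 3 `CCCCNc1nc(N)nc2c1CN(Cc1cc(F)cc(F)c1)CC2` gives 0.23 uM. Both of these carry an aryl group on the saturated chain carbon bound to the amine nitrogen in the ring, and both changes raised the number, a 4.7-fold higher number from compound 1 to compound 2 (0.67 log units; beyond the scatter) and a 7.7-fold higher number from compound 1 to compound 3 (0.88 log units; beyond the scatter); the two aryl compounds themselves sit close together, a 1.6-fold higher number from compound 2 to compound 3 (0.22 log units; within the scatter).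

Compound 4 `CCCCNc1nc(N)nc2c1CN(C(=O)CC)CC2` has not yet been measured in this assay. It differs from compound 1 in one place: propanoyl in place of methyl on an amine nitrogen in a ring. Going by the values given here, no measured step exchanges the methyl itself; the two steps that touch the same part of the core, from compound 1 to compound 2 and from compound 1 to compound 3, only add an aryl to its carbon, and each raised the number modestly. Among the compounds with values here, the data therefore give no direct precedent for an acyl group on that nitrogen, only a sign that enlarging what sits there tends to raise the number. Compound 4 is accordingly expected to show a modest rise, a 3.3-fold higher number from compound 1 to compound 4 (0.52 log units; beyond the scatter). The estimate for compound 4 in this assay is 0.1 uM, with a range from 0.03 uM to 0.5 uM.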

Compound 4, minimum effective concentration: 0.4 uM
Compound 4: middle estimate off by 4.0-fold (0.60 log units), on the low side; low and high end bracket the measured number.
By their numbers in this assay, from the lowest: compound 1; then compounds 2, 3 and 4 (each within the scatter of the next, the first and the last beyond it).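

On an amine nitrogen in a ring, propanoyl in place of methyl gives a 13-fold higher number from compound 1 to compound 4 (1.12 log units; beyond the scatter), a large step, and it shows that a group with no ring, carrying a carbonyl, can raise the number here as well. The number of compound 4 lies within the scatter of that of compound 3, whose aryl group gave a 7.7-fold higher number from compound 1 to compound 3 (0.88 log units; beyond the scatter), so an aryl group is not required for a rise of this order, and in all three compounds with a larger group on this nitrogen the number lies beyond the scatter of that of compound 1, with none going against this. Nothing in the available data accounts for the size of this rise, or tells whether it comes from the carbonyl or from the longer chain.

The compounds shown leave open how a plain propyl group on this nitrogen, with no carbonyl, would compare with propanoyl, and the same holds for the shorter acetyl group. They also leave open what a bare hydrogen on this nitrogen would give in place of the methyl of compound 1.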